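The source may report more compounds than this note shows. Statements on the series, on what has been measured and on what is new or still open speak of the compounds shown alone.

In a functional assay on MCF7 cells (Homo sapiens) for inhibition, read by MTT assay, with a stated time of 72 h (on this read-out lower numbers stand for stronger inhibition and higher numbers for weaker inhibition), compound 1 (`O=C(Nc1cccc(Br)c1)C1CCN(C/C=C/c2ccccc2)CC1`) gives 11500 nM and compound 2 (`O=C(Nc1ccc(F)c(Br)c1)C1CCN(C/C=C/c2ccccc2)CC1`) gives 13500 nM, so compound 2 stands within the scatter of compound 1. Compound 3 (`O=C(Nc1ccccn1)C1CCN(C/C=C/c2ccccc2)CC1`) differs from compound 2 by pyridin-2-yl in place of 3-bromo-4-fluorophenyl on an amide-type nitrogen. For the measured compounds named here, the only measured step, a 1.2-fold higher number from compound 1 to compound 2 (0.07 log units; within the scatter), is fluoro in place of hydrogen on an aromatic carbon and bears only weakly, since no measured compound carries pyridin-2-yl. A modest move towards a higher number in this assay is therefore expected, with little confidence: a 1.5-fold higher number from compound 2 to compound 3 (0.17 log units; within the scatter) is the estimated step. For compound 3 the estimated value is 20000 nM, with an expected range of 8000 nM to 50000 nM.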

Compound 3, half-maximal inhibitory concentration: 67200 nM
Beside the measured number, compound 3's estimate is 3.4-fold (0.53 log units) below it; measured number outside the range, above it.
By their numbers in this assay, from the lowest: compounds 1 and 2 (each within the scatter of the next); then compound 3.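

In this assay, for the compounds shown here, the group on the amide-type nitrogen is the first place where a change goes beyond the scatter. Pyridin-2-yl in place of 3-bromo-4-fluorophenyl gives a 5.0-fold higher number from compound 2 to compound 3 (0.70 log units; beyond the scatter), and pyridin-2-yl in place of 3-bromophenyl gives a 5.8-fold higher number from compound 1 to compound 3 (0.77 log units; beyond the scatter), so both steps point the same way. No measured evidence bears on the reason for this rise.

From the compounds shown here alone, whether the steps follow the loss of the bromo or the entry of the ring nitrogen stays open, as both change together in compound 3. Where a plain phenyl or a pyridin-3-yl would stand on this nitrogen also remains open.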